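The source may hold more compounds than are shown below. What is called first, only, known or untested is meant among the compounds shown, and "the series" means these compounds.

Going by the values given here, in a functional assay (muscle tissue) with Cavia porcellus as the target (on this read-out lower numbers stand for an effect already at smaller amounts and higher numbers for an effect only at larger amounts of compound), compound 3 `COC(=O)C1=C(C)N=C(C)/C(=C(\O)OC)C1c1ccc(C#N)cc1` gives 3470 nM, the highest of the three numbers so far. Compound 2 `COC(=O)C1=C(C)N=C(C)/C(=C(\O)OC)C1c1cccc(C(F)(F)F)c1` gives 74.1 nM, and compound 1 `CCc1ccccc1C1C(C(=O)OC)=C(C)N=C(C)/C1=C(\O)OC` gives 6.46 nM, the lowest. Compound 4 `COC(=O)C1=C(C)N=C(C)/C(=C(\O)OC)C1c1cccc(I)c1` has 3-iodophenyl in place of 4-cyanophenyl on a saturated ring carbon. One measured step changes the same place and also removes 4-cyanophenyl. It is a 540-fold higher number from compound 1 to compound 3 (2.73 log units; beyond the scatter), read in reverse here, and it is large and beyond the scatter. Among the measured compounds, the aryl group closest to that of compound 4 is that of compound 2. The number of compound 3 lies well above that of compound 2, which gives 74.1 nM. Among the compounds with values here, a large move to a lower number in this assay is therefore expected, though smaller than the measured step, since no measured compound carries iodine. The estimated change is an 87-fold lower number from compound 3 to compound 4 (1.94 log units; beyond the scatter). For compound 4 the expected value is about 40 nM, with an estimated range of 8 nM to 200 nM.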

Compound 4, half-maximal effective concentration: 41.7 nM
Compound 4: middle estimate off by 1.0-fold (0.02 log units), on the low side; the measured number falls inside the stated range.
By their numbers in this assay, from the lowest: compound 1; then compounds 4 and 2 (each within the scatter of the next); then compound 3.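

In this assay, the change from 4-cyanophenyl to 3-iodophenyl on the saturated ring carbon gives an 83-fold lower number from compound 3 to compound 4 (1.92 log units; beyond the scatter), so the high number of compound 3 is not shared by every aryl group other than 2-ethylphenyl at this position. Iodo in place of trifluoromethyl on an aromatic carbon gives a 1.8-fold lower number from compound 2 to compound 4 (0.25 log units; within the scatter), so these two groups cannot be told apart here, while a 6.5-fold higher number from compound 1 to compound 4 (0.81 log units; beyond the scatter) shows that a modest gap to 2-ethylphenyl remains. Nothing measured here accounts for these differences.

On these data alone, how a 3-cyanophenyl or a 4-iodophenyl group would read remains open, and with it whether the nitrile or its place on the aryl ring sets compound 3 apart. Also open, as far as these compounds go, is how an amine or a carboxylic acid on that aryl ring, or a longer chain in place of the ethyl group of compound 1, would read in this assay.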